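This account rests on a few compounds, and the source may have more. Where it says the series, first, only, none or still open, it means among the compounds named here.

Measured so far:
compound 1 `Cc1ccc(Cc2cn3cc(Cl)ccc3nc2=O)cc1` gives > 1000000 nM (a limit)
compound 2 `CC1(C)OC2O[C@@H](Cc3cn4ccccc4nc3=O)C(OCc3ccccc3)C2O1` gives > 1000000 nM (a limit)

In a functional assay on HepG2 cells (Homo sapiens) for cytotoxicity, read by MTT assay, with a stated time of 24 h (a lower number here means a stronger inhibitor, a higher number a weaker inhibitor), compound 1 gives > 1000000 nM, which is a limit of the assay and not a number. Compound 1 therefore has no exact position in the series. Compound 2 gives > 1000000 nM, which is also only a limit. The whole measured set sits at one point: the limit of > 1000000 nM in this assay, at which 2 of the 2 values shown sit. No graded potency can be read from these data.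

The next compound is compound 3 `O=c1nc2ccc(Cl)cn2cc1Cc1ccc([N+](=O)[O-])cc1`, which keeps the core of compound 1 and carries nitro in place of methyl on an aromatic carbon, para to a large group: nitro in place of methyl on an aromatic carbon. Among the compounds with values here, no measured pair isolates this change, so its size has to be estimated. Within the data shown here, the only anchor is compound 1 at > 1000000 nM, so no shift beyond the usual scatter is expected in this assay, and a report of only a limit is the likeliest outcome. The expected change is a number no higher from compound 1 to compound 3 (the limit leaves the size open). The estimated value for compound 3 is 1000000 nM. The expected range for compound 3 runs from 300000 nM to 2000000 nM.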

Compound 3, half-maximal inhibitory concentration: > 1000000 nM
Compound 3: a limit, no number (the forecaster's own chance of this, stated with the estimate: 70%); the middle value lies on the limit itself.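

In this assay, compound 1 and compound 3 each give only a limit and not a number, so no step can be read between them. The series stays at a single point: the limit of > 1000000 nM in this assay, at which 3 of the 3 values shown sit.

The compounds shown leave open how large the change of nitro in place of methyl is, and whether any compound in the series gives a graded value in this assay.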